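This account rests on a few compounds, and the source may have more. Where it says the series, first, only, none or still open, it means among the compounds named here.

The measured compounds in an assay on isolated protein for inhibition of ubiquitin carboxyl-terminal hydrolase 7 (Homo sapiens), with stated times of 30 min and 2 h; on this read-out higher numbers stand for weaker inhibition and lower numbers for stronger inhibition:
compound 1 `Cn1nc2c(=O)n(CC3(O)CCN(Cc4ccc(-c5cncs5)cc4Cl)CC3)cnc2c1-c1ccc(CN)cc1` gives 117 nM
compound 2 `Cn1nc2c(=O)n(CC3(O)CCN(Cc4ccc(-c5ccsc5)cc4Cl)CC3)cnc2c1-c1ccc(CN)cc1` gives 59.5 nM
compound 3 `Cn1nc2c(=O)n(CC3(O)CCN(Cc4ccc(-c5ccc[nH]5)cc4Cl)CC3)cnc2c1-c1ccc(CN)cc1` gives 193 nM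

Compound 3 has the highest number of the three; its nearest neighbour is compound 1, with a 1.6-fold higher number from compound 1 to compound 3 (0.22 log units; within the scatter), and its furthest is compound 2, with a 3.2-fold higher number from compound 2 to compound 3 (0.51 log units; beyond the scatter). Compound 4 `Cn1nc2c(=O)n(CC3(O)CCN(Cc4ccc(-n5cccn5)cc4Cl)CC3)cnc2c1-c1ccc(CN)cc1` differs from compound 3 in one place: 1H-pyrazol-1-yl in place of 1H-pyrrol-2-yl on an aromatic carbon. The two steps that bear on this exchange are the ones that swapped one five-membered ring for another at the same aromatic carbon, a 1.6-fold higher number from compound 1 to compound 3 (0.22 log units; within the scatter) and a 3.2-fold higher number from compound 2 to compound 3 (0.51 log units; beyond the scatter), both small to modest. A step of similar size, with no clear direction, is therefore expected in this assay: compound 4 is estimated at 130 nM, between 55 nM and 310 nM, which corresponds to an expected 1.5-fold lower number from compound 3 to compound 4 (0.17 log units; within the scatter).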

Compound 4, half-maximal inhibitory concentration: 233 nM
The estimate for compound 4 lay 1.8-fold (0.25 log units) below the measured number; low and high end bracket the measured number.
By their numbers in this assay, from the lowest: compounds 2, 1, 3 and 4 (each within the scatter of the next, the first and the last beyond it).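

Replacing 1H-pyrrol-2-yl, which carries a hydrogen-bond donor, with 1H-pyrazol-1-yl, which carries none, leaves the number in this assay within the scatter (a 1.2-fold higher number from compound 3 to compound 4 (0.08 log units; within the scatter)). The step from the thiazole compound also stays within it (a 2.0-fold higher number from compound 1 to compound 4 (0.30 log units; within the scatter)), so this aromatic carbon, para to a large group, accepts a ring with two hetero atoms without a clear change. Only thiophen-3-yl stands apart from compound 4 (a 3.9-fold higher number from compound 2 to compound 4 (0.59 log units; beyond the scatter)).

No measurement shown explains these steps. Going by these compounds, what an amine, a carboxylic acid or a six-membered ring such as pyridinyl would do at this carbon stays open.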